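Swapping tert-butyl for 2-chloroethyl on the carbonyl carbon

The compounds below may be only part of what the source reports. "The series", "measured", "known", "first", "only" and "open" are said of these compounds alone.

Compound 1, `CCC(=O)Nc1cccc(S(=O)(=O)Oc2ccccc2C(C)C)c1`: in a functional assay on HT-29 cells (Homo sapiens) for antiproliferative activity, read by sulforhodamine B assay, with a stated time of 48 h (a higher number here means a weaker inhibitor, a lower number a stronger inhibitor), compound 1 gives 22000 nM.
Compound 2, `CCCC(=O)Nc1cccc(S(=O)(=O)Oc2ccccc2C(C)C)c1`: in this assay compound 2 gives 13000 nM.
Compound 3, `CC(C)c1ccccc1OS(=O)(=O)c1cccc(NC(=O)C(C)(C)C)c1`: in this assay compound 3 gives 19000 nM.

The three measured compounds share one core and differ only in the group on the carbonyl carbon. Compound 3 stands second highest of the three numbers, yet every step among them stays within the scatter: a 1.7-fold lower number from compound 1 to compound 2 (0.23 log units; within the scatter), a 1.2-fold lower number from compound 1 to compound 3 (0.06 log units; within the scatter) and a 1.5-fold higher number from compound 2 to compound 3 (0.16 log units; within the scatter). Compound 4, `CC(C)c1ccccc1OS(=O)(=O)c1cccc(NC(=O)CCCl)c1`, has not yet been measured. It differs from compound 3 in one place: 2-chloroethyl in place of tert-butyl on a carbonyl carbon. All three measured steps bear on this change; each of them also swaps the group on the same carbonyl carbon, and none of them moved the number beyond the scatter. The change to a 2-chloroethyl group is therefore expected to leave this assay about where compound 3 sits, with no step beyond the scatter in either direction. The step expected here is a 1.1-fold lower number from compound 3 to compound 4 (0.05 log units; within the scatter). For compound 4 the estimate is 17000 nM, with a range from 6000 nM to 50000 nM.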

Compound 4, half-maximal inhibitory concentration: 11000 nM
Compound 4: the middle estimate sits 1.5-fold (0.19 log units) above what was measured, and the stated range covers the measured number.
By their numbers in this assay, from the lowest: compounds 4, 2, 3 and 1 (each within the scatter of the next).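

Among these compounds, compound 4 puts a chlorine-bearing group on this carbonyl carbon for the first time, and in this assay the number stays within the scatter of all three earlier compounds (a 1.7-fold lower number from compound 3 to compound 4 (0.24 log units; within the scatter); a 1.2-fold lower number from compound 2 to compound 4 (0.07 log units; within the scatter); a 2.0-fold lower number from compound 1 to compound 4 (0.30 log units; within the scatter)). The flat picture seen with ethyl, propyl and tert-butyl therefore extends from groups of carbon alone to 2-chloroethyl, and the step from compound 1 to compound 4 is the largest among these four yet still not beyond the scatter. No measurement here offers an explanation for this flat picture.

Groups on this carbonyl carbon that contain a ring, such as phenyl, or that end in an amine or a carboxylic acid, remain open. So does whether any group at this position can move the number beyond the scatter.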